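This account rests on a few compounds, and the source may have more. Where it says the series, first, only, none or still open, it means among the compounds named here.

Working notes on the series.

The compounds share one core, seen in compound 1 `CCOC(=O)C1=Cc2ccccc2OC1(OCc1cc(-c2ccc(C)cc2)no1)C(F)(F)F` and in compound 2 `CCOC(=O)C1=Cc2ccccc2OC1(OCc1cn(-c2cccc(OC)c2)nn1)C(F)(F)F`. Both have been run in a functional assay on DU-145 cells (Homo sapiens) for inhibition, read by MTT assay, with a stated time of 24 h; on this read-out lower numbers stand for stronger inhibition and higher numbers for weaker inhibition. Compound 1 gives only a limit of the assay there, at > 150000 nM, and no number. Compound 2 likewise gives only a limit in this assay, at > 150000 nM, and no number. Where compound 2 stands is therefore fixed only by that limit, and both values shown in this assay sit at the same point, as recorded by the limit of > 150000 nM in this assay, at which 2 of the 2 values shown sit. Among the measured compounds shown here, no step between measured compounds is available.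

Compound 3 `CCOC(=O)C1=Cc2ccccc2OC1(OCc1cn(-c2cccc(C(F)(F)F)c2)nn1)C(F)(F)F` is not yet measured. It differs from compound 2 as follows: trifluoromethyl in place of methoxy on an aromatic carbon. The change is a trifluoromethyl entering for a methoxy on an aromatic carbon, with the wider reading 3-methoxyphenyl to 3-(trifluoromethyl)phenyl.

For the measured compounds named here, with no measured step in hand, compound 3 is expected to stay at the limit, and the step of a number no higher from compound 2 to compound 3 (the limit leaves the size open) is estimated as none beyond the scatter. Compound 3 is accordingly estimated at 150000 nM in this assay, within 50000 nM to 500000 nM.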

Compound 3, half-maximal inhibitory concentration: > 150000 nM
Compound 3: a limit, no number; the forecaster's own chance of this, stated with the estimate: 85%; the middle value lies on the limit itself.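

In this assay, among the compounds shown here, compound 3 gives only a limit, > 150000 nM, and compound 2 also gives only a limit, so no step between compound 2 and compound 3 can be read. The compounds shown leave open how trifluoromethyl and methoxy compare here, and whether any compound shown would give a number rather than a limit: the limit of > 150000 nM in this assay, at which 3 of the 3 values shown sit.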